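A few compounds are considered here, and "the series" means these few. Any claim that something is new, unique, unknown or untested is made for them only; others in the source may bear on it.

This account follows one change made to compound 1 `CN(C[C@H]1Cc2c(cccc2N2CCN(Cc3ccccn3)CC2)CN1)[C@H]1CCCc2cccnc21`. In a functional assay on CCRF-CEM cells for agonist activity at C-X-C chemokine receptor type 4 (Homo sapiens), read by calcium flux, with a stated time of 25 min (a higher number here means that more compound is needed for the effect, a lower number that less compound is needed), compound 1 gives only a limit, > 30000 nM. Two close relatives are measured alongside it. Compound 2 `CCCN(C[C@H]1Cc2c(cccc2N2CCNCC2)CN1)[C@H]1CCCc2cccnc21` gives in this assay only a limit as well, > 30000 nM. Compound 3 `CN1CCN(c2cccc3c2C[C@H](CN(C)[C@H]2CCCc4cccnc42)N(C)C3)CC1` likewise gives in this assay only a limit, > 30000 nM. Compound 1 therefore stands at the limit, and the whole of what has been measured sits there with it: the limit of > 30000 nM in this assay, at which 3 of the 3 values shown sit. For the measured compounds named here, no step between two measured compounds carries a number on both sides, so nothing shows how any change moves the read-out in this assay.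

The compound still to be measured is compound 4 `CN(C[C@H]1Cc2c(cccc2N2CCN(c3ncccn3)CC2)CN1)[C@H]1CCCc2cccnc21`. It differs from compound 1 in a single place: pyrimidin-2-yl in place of (pyridin-2-yl)methyl on an amine nitrogen in a ring. Going by the values given here, because every value recorded sits at the limit, (the limit of > 30000 nM in this assay, at which 3 of the 3 values shown sit), no change beyond the usual scatter is expected, and the step of a number no higher from compound 1 to compound 4 (the limit leaves the size open) in this assay is estimated to be no step at all. For compound 4 the estimate in this assay is 30000 nM, expected to fall between 10000 nM and 100000 nM, most likely reported once more only as a limit.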

Compound 4, half-maximal effective concentration: > 30000 nM
Compound 4: a limit, no number (the forecaster's own chance of this, stated with the estimate: 85%); the middle value sits exactly at the limit.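

Compound 4 gives in this assay only a limit, > 30000 nM. For the compounds shown here, compound 1 gives only a limit as well, so no step from one to the other can be read. The compounds shown leave open whether pyrimidin-2-yl and (pyridin-2-yl)methyl differ at all in this assay, and whether any compound here gives a measurable number: the limit of > 30000 nM in this assay, at which 4 of the 4 values shown sit.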